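Cyclopropyl in Place of Chlorophenyl on the Ring Nitrogen

A few compounds are considered here, and "the series" means these few. Any claim that something is new, unique, unknown or untested is made for them only; others in the source may bear on it.

Compound 2 `O=C1COc2ccc(-c3cnc(Cl)c(NS(=O)(=O)c4ccc(F)cc4)c3)cc2N1c1ccc(Cl)cc1` belongs to a small set of compounds sharing one core, all tested in a functional assay on A549 cells (Homo sapiens) for antiproliferative activity, read by MTT assay, with a stated time of 72 h; a higher number here means a weaker inhibitor, a lower number a stronger inhibitor. In that test compound 2 gives 21600 nM. Within the data shown here, compound 3 `COc1ncc(-c2ccc3c(c2)N(c2ccc(Cl)cc2)C(=O)CO3)cc1NS(=O)(=O)c1ccc(F)cc1` gives 8350 nM, and the single change here, methoxy in place of chloro on an aromatic carbon, amounts to a 2.6-fold lower number from compound 2 to compound 3 (0.41 log units; beyond the scatter). Compound 1 `O=C1COc2ccc(-c3cnc4ccccc4c3)cc2N1c1ccccc1` gives > 40000 nM, which is a limit of the assay and not a number; it sits at the limit of > 40000 nM in this assay, at which 1 of the 3 values shown sits. Among the two real numbers, compound 2 therefore stands highest, with compound 3 as its only measured neighbour.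

Compound 4 `O=C1COc2ccc(-c3cnc(Cl)c(NS(=O)(=O)c4ccc(F)cc4)c3)cc2N1C1CC1` has not yet been measured. Relative to compound 2 its change is cyclopropyl in place of 4-chlorophenyl on an amide-type nitrogen in a ring. Among the measured compounds shown here, no measured step touches this part of the core: the one step on record, from compound 2 to compound 3, alters a group on an aromatic carbon elsewhere in the molecule, and the limit for compound 1 gives no scale at all. With nothing to lean on, the expected step from compound 2 to compound 4 is a 1.0-fold higher number from compound 2 to compound 4 (0.01 log units; within the scatter), which is to say none beyond the scatter. Compound 4 is accordingly estimated at about 22000 nM, with a range from 7000 nM to 70000 nM.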

Compound 4, half-maximal inhibitory concentration: 4330 nM
Compound 4: the middle estimate sits 5.1-fold (0.71 log units) above what was measured, outside the stated range (below it).
By their numbers in this assay, from the lowest: compounds 4 and 3 (each within the scatter of the next); then compound 2. At a limit, above all of these: compound 1.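

Among these compounds, the ring nitrogen, which no earlier step touched, proves to be a place where a change moves the result in this assay: cyclopropyl in place of 4-chlorophenyl gives a 5.0-fold lower number from compound 2 to compound 4 (0.70 log units; beyond the scatter). In this one pair, the six-membered aromatic ring on that nitrogen is therefore not needed for the activity seen, and a three-membered carbon ring with 3 heavy atoms in place of 7 gives the lower number, meaning the stronger inhibitor. Nothing measured here accounts for why this exchange lowers the number.

Among the compounds shown here, with only one pair at this position, the result cannot separate the loss of the chlorine, the loss of the aromatic ring and the drop in heavy atoms, and a plain methyl, an isopropyl or a cyclohexyl group on the same nitrogen would be needed to pull these apart. Going by these compounds, it also remains open whether an amine carried on a longer chain at this nitrogen would fit the same trend, and whether cyclopropyl and the methoxy group of compound 3 would work together in a single molecule.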